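A nitro group in place of dimethylamino on the chain end

The source may report more compounds than this note shows. Statements on the series, on what has been measured and on what is new or still open speak of the compounds shown alone.

Of the compounds shown here, three sharing one core have been measured so far. Within the data shown here, compound 3, with structure `COc1ccc(C(=O)/C=C/c2ccc(N(C)C)cc2)c2c1C=CC(C)(C)O2`, is the only one that gives a number in a functional assay on K562 cells (Homo sapiens) for antiproliferative activity, read by MTT assay, with a stated time of 24 h; on this read-out lower numbers stand for stronger inhibition and higher numbers for weaker inhibition: compound 3 gives 3500 nM. Compound 1, with structure `COc1cccc(/C=C/C(=O)c2ccc(OC)c3c2OC(C)(C)C=C3)c1`, reaches only a limit of this assay, since compound 1 gives > 10000 nM. Compound 2, with structure `COc1ccc(C(=O)/C=C/c2ccc(Br)cc2)c2c1C=CC(C)(C)O2`, likewise gives only a limit, as compound 2 gives > 10000 nM. Among the measured compounds shown here, compound 3 therefore stands alone as the one compound with a readable number.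

Two steps lead to compound 3. There is an at least 2.8-fold lower number from compound 1 to compound 3 (0.45 log units; beyond the scatter), and there is an at least 2.8-fold lower number from compound 2 to compound 3 (0.45 log units; beyond the scatter). Both show that the dimethylamino-bearing ring goes with a lower number than either the methoxy- or the bromo-bearing ring, which both sit at the limit of > 10000 nM in this assay, at which 2 of the 3 values shown sit.

The unmeasured compound 4, with structure `COc1ccc(C(=O)/C=C/c2cccc([N+](=O)[O-])c2)c2c1C=CC(C)(C)O2`, differs from compound 3 by 3-nitrophenyl in place of 4-(dimethylamino)phenyl on a double-bonded chain carbon bound to a double-bonded chain carbon. This removes the very group that the two measured steps connect with the lower number, and the two compounds without it both end at the limit. The number for compound 4 is therefore expected to rise, so that the step of a 2.6-fold higher number from compound 3 to compound 4 (0.41 log units; beyond the scatter) is estimated. Compound 4 is expected to give about 9000 nM, with a range from 3000 nM to 30000 nM.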

Compound 4, half-maximal inhibitory concentration: 5870 nM
Compound 4: middle estimate off by 1.5-fold (0.19 log units), on the high side, and the stated range covers the measured number.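

Until now, only the 4-(dimethylamino)phenyl group at this place on a double-bonded chain carbon had given a readable number in this assay, but 3-nitrophenyl gives one as well, and there is a 1.7-fold higher number from compound 3 to compound 4 (0.22 log units; within the scatter). The dimethylamino group is therefore not required for a readable number on this core, and this assay does not separate these two compounds, even though the groups that differ between them are of quite different make-up. Compared with the other two compounds there is an at least 1.7-fold lower number from compound 2 to compound 4 (0.23 log units; that floor lies within the scatter), and there is also an at least 1.7-fold lower number from compound 1 to compound 4 (0.23 log units; that floor lies within the scatter), but compound 1 and compound 2 each stop at a limit rather than a number, so neither step gives a true size: the limit of > 10000 nM in this assay, at which 2 of the 4 values shown sit.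

Compound 3 and compound 4 differ in both the group and its printed ring number, so the compounds shown cannot tell whether either change alone would matter, and a 4-nitrophenyl or 3-(dimethylamino)phenyl group would be needed to pull the two apart. Also open, as far as these compounds go, is what a primary amine or a carboxylic acid on the same ring would give in this assay.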